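A Bromo Substituent in Place of Methoxy on the Phenyl

This account rests on a few compounds, and the source may have more. Where it says the series, first, only, none or still open, it means among the compounds named here.

The measured compounds:
compound 1, `O=C(/C=C\c1ccccc1O)N1N=C(c2ccncc2)OC1c1c[nH]c2ccccc12`, gives 26.8 ug/mL in an ADME assay on HeLa cells (Homo sapiens) for cytotoxicity, read by MTT assay, with a stated time of 72 h; on this read-out lower numbers stand for stronger inhibition of growth and higher numbers for weaker inhibition of growth;
compound 2, `COc1ccc(/C=C\C(=O)N2N=C(c3ccncc3)OC2c2c[nH]c3ccccc23)cc1`, gives > 30 ug/mL in this assay;
compound 3, `O=C(/C=C\c1cccc(Cl)c1Cl)N1N=C(c2ccncc2)OC1c1c[nH]c2ccccc12`, gives > 30 ug/mL in this assay.

Compound 2 stands at the upper limit of this assay rather than at a number: its value is a limit, as the line the limit of > 30 ug/mL in this assay, at which 2 of the 3 values shown sit, shows, and so its own position is only bounded from below. Compound 4, `O=C(/C=C\c1ccc(Br)cc1)N1N=C(c2ccncc2)OC1c1c[nH]c2ccccc12`, differs from compound 2 in one place: bromo in place of methoxy on an aromatic carbon.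

Among the measured compounds shown here, three measured steps touch the same phenyl. From the compound with a 2-hydroxyphenyl the move to a 4-methoxyphenyl gave an at least 1.1-fold higher number from compound 1 to compound 2 (0.04 log units; that floor lies within the scatter), and the move to a 2,3-dichlorophenyl gave an at least 1.1-fold higher number from compound 1 to compound 3 (0.04 log units; that floor lies within the scatter). Between the two limit compounds the step that the two limits leave unreadable from compound 2 to compound 3 cannot be sized. For the measured compounds named here, no measured step exchanges a methoxy for a bromo, so nothing in these numbers points to a shift beyond the scatter in either direction in this assay for compound 4.

Compound 4 is therefore expected to sit near the limit as well, with an estimated value of 30 ug/mL, between 15 ug/mL and 60 ug/mL. This estimate for compound 4 means a step of a number no higher from compound 2 to compound 4 (the limit leaves the size open), expected to lie within the scatter.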

Compound 4, concentration for 50% growth inhibition: > 30 ug/mL
Compound 4 gave a limit, no number (the forecaster's own chance of this, stated with the estimate: 60%); the middle value lies on the limit itself.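

Compound 4 gives > 30 ug/mL in this assay, and this value is a limit, not a number. With the 4-bromophenyl, a third group on this phenyl now leaves the compound at that limit, so neither the 4-methoxyphenyl to 4-bromophenyl change nor the change from the 2,3-dichlorophenyl gives a size, and the steps to compound 4 from compound 2 and from compound 3 cannot be read: the limit of > 30 ug/mL in this assay, at which 3 of the 4 values shown sit. Among the compounds shown here, the one step that can be read is an at least 1.1-fold higher number from compound 1 to compound 4 (0.04 log units; that floor lies within the scatter) and, with its floor inside the scatter, it does not establish that the 4-bromophenyl differs from the 2-hydroxyphenyl of compound 1.

From the compounds shown here alone, what remains open is how far compound 2, compound 3 and compound 4 really lie from one another, and whether the bromo and the methoxy differ at all on this read-out, since the limit hides any such gap. Going by these compounds, it is also open whether an amine or a carboxylic acid on this phenyl, or a longer chain in place of the ethenyl link, would give a value that can be read as a number.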